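The source may hold more compounds than are shown below. What is called first, only, known or untested is meant among the compounds shown, and "the series" means these compounds.

Measured so far:
compound 1, `CC(C)Cc1ccc(C(C)c2nnc3sc(COc4ccc(Cl)cc4Cl)nn23)cc1`: 38.6%
compound 2, `CCCCNc1nn2c(C(C)c3ccc(CC(C)C)cc3)nnc2s1`: 80.3%

Both numbers come from a functional assay on the whole organism (strain Wistar albino) for inhibition, with Rattus norvegicus as the target, read by paw edema, with a stated time of 4 h, at a dose of 70 mg/kg by the oral route; a lower number here means less inhibition, a higher number more inhibition at the dose given (going by the name of the read-out). Compound 2 stands highest of the two, with the gap to compound 1 beyond the scatter: a number 41.7 percentage points higher from compound 1 to compound 2 (beyond the scatter). Compound 3, `Cc1ccc(Nc2nn3c(C(C)c4ccc(CC(C)C)cc4)nnc3s2)c(C)c1`, is not yet measured. It differs from compound 2 in one place: 2,4-dimethylphenyl in place of butyl on a nitrogen on an aromatic ring. Within the data shown here, no measured step changes the group on this nitrogen, so the single step in hand, the exchange of (2,4-dichlorophenoxy)methyl for butylamino from compound 1 to compound 2, bears on compound 3 only indirectly: it shows that the substituent at this side of the core can move the read-out by a large amount. A step in this assay is therefore expected for compound 3, most likely a moderate fall rather than a rise, a number 15.3 percentage points lower from compound 2 to compound 3 (beyond the scatter), but with a wide range. Compound 3 is estimated at 65%, between 45% and 85%.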

Compound 3, a percentage reported as inhibition, in the whole organism at one dose (the size of the read-out at that dose, not a potency): 53%
Compound 3: the middle estimate sits 12 percentage points above what was measured; the measured number falls inside the stated range.
By their numbers in this assay, from the lowest: compound 1; then compound 3; then compound 2.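

On a nitrogen on an aromatic ring, the identity of the group matters in this assay: 2,4-dimethylphenyl in place of butyl gives a number 27.3 percentage points lower from compound 2 to compound 3 (beyond the scatter), so keeping the amino link does not by itself hold the read-out. (2,4-Dimethylphenyl)amino still reads better than (2,4-dichlorophenoxy)methyl on the aromatic carbon, with a number 14.4 percentage points higher from compound 1 to compound 3 (beyond the scatter), so an amino-linked ring retains only part of the advantage seen with butylamino. Nothing at hand explains why the ring-bearing group reads lower than the butyl chain.

Still open, as far as these compounds go, is whether the fall belongs to the ring itself or to its two methyl groups, which an unsubstituted phenyl on this nitrogen would separate. Also open, from the compounds shown here alone, is how a shorter chain such as ethyl, a longer chain such as hexyl, or a saturated ring such as cyclohexyl would read here.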